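The compounds below may be only part of what the source reports. "The series", "measured", "known", "first", "only" and "open" are said of these compounds alone.

Compound 3, with the structure `COc1cc(C(c2ccc(O)c(OC)c2)[C@H](CC(C)C)C(C)C)ccc1O`, gives 9600 nM in a functional assay on HL-60 cells (Homo sapiens) for cytotoxicity, read by WST assay, with a stated time of 48 h; a higher number here means a weaker inhibitor, a lower number a stronger inhibitor. Among the numbers known here, that is the lowest: compound 1, with the structure `COc1cc(C(c2ccc(O)c(OC)c2)[C@H](C)[C@H](C)CF)ccc1O`, gives 56000 nM in this assay. Compound 2, with the structure `COc1ccc(C(c2ccc(OC)c(OC)c2)[C@H](C)[C@H](C)CO)cc1OC`, gives only a limit of this assay, > 100000 nM, and no number. Measured step: a 5.8-fold lower number from compound 1 to compound 3 (0.77 log units; beyond the scatter).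

Compound 4, with the structure `COc1cc(C(c2ccc(O)c(OC)c2)[C@@H](CF)C(C)C)ccc1O`, has not yet been measured. It differs from compound 3 in one place: 1-(fluoromethyl)-2-methylpropyl in place of 1-isopropyl-3-methylbutyl on a saturated chain carbon bound to two aromatic carbons. For the measured compounds named here, the only measured step that bears on this change is the one from compound 1 to compound 3, in which a fluoromethyl-bearing group of the same kind gave way to the larger 1-isopropyl-3-methylbutyl group and the number fell by a modest but clear amount. The change from compound 3 to compound 4 runs roughly the other way, bringing back a smaller group that carries a fluoromethyl. The expectation is therefore a step upward, of a size close to the earlier one reversed, so that compound 4 should land between compound 3 and compound 1: an estimated 3.1-fold higher number from compound 3 to compound 4 (0.49 log units; beyond the scatter) in this assay. Compound 4 is expected to give about 30000 nM in this assay, within a range from 12000 nM to 80000 nM.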

Compound 4, half-maximal inhibitory concentration: 39000 nM
The estimate for compound 4 lay 1.3-fold (0.11 log units) below the measured number, within the range that was stated.
By their numbers in this assay, from the lowest: compound 3; then compounds 4 and 1 (each within the scatter of the next). At a limit, above all of these: compound 2.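

In this assay, swapping out the 1-isopropyl-3-methylbutyl group for the 1-(fluoromethyl)-2-methylpropyl group gives a 4.1-fold higher number from compound 3 to compound 4 (0.61 log units; beyond the scatter) and confirms, from a second fluorine-bearing group, that this position responds to the change of group. For the compounds shown here, the earlier compounds offered only one such comparison, and that one started from 2-(fluoromethyl)-1-methylpropyl. The two fluorine-bearing groups can now be compared directly, and a 1.4-fold lower number from compound 1 to compound 4 (0.16 log units; within the scatter) means that this assay does not separate them, so compound 3 stays apart from both compound 1 and compound 4.

Each step into or out of compound 3 replaces the whole group at once, so the fluorine cannot be separated from the rest of the group, and a matching chain with a hydroxymethyl or a plain methyl in place of the fluoromethyl would be needed to tell these apart. The one limit shown belongs to a compound that differs in more than one place, and nothing measured here gives a reason for either step.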